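Alpha-methyl branching on the acid chain of the aza core

This account rests on a few compounds, and the source may have more. Where it says the series, first, only, none or still open, it means among the compounds named here.

Three analogues share a bicyclic core carrying a pyridyl group and a phenyl ring that bears a carboxylic acid chain. Compound 1 `Cc1nn(-c2ccccn2)c2cc(-c3ccc(CCC(=O)O)cc3)ccc12` has the carbon core, compound 3 `CCc1nn(-c2ccccn2)c2cc(-c3ccc(CCC(=O)O)cc3)ccc12` differs from it by methyl in place of hydrogen on a saturated chain carbon bound to an aromatic carbon, and compound 2 `Cc1nn(-c2ccccn2)c2cc(-c3ccc(CCC(=O)O)cc3)ncc12` carries a nitrogen in the core ring; the difference between the two cores is not broken down here. In a functional assay on cells for agonist activity at Free fatty acid receptor 1 (Mus musculus), read by FLIPR and calcium flux, with a stated time of 5 min (on this read-out higher numbers stand for an effect only at larger amounts of compound and lower numbers for an effect already at smaller amounts), compound 1 gives 1400 nM, compound 3 gives 1100 nM and compound 2 gives 9200 nM. The step of a 1.3-fold lower number from compound 1 to compound 3 (0.10 log units; within the scatter) is small. Compound 2 stands with the highest number of the three, and its gaps to compound 1 and compound 3 are both beyond the scatter.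

Compound 4 `Cc1nn(-c2ccccn2)c2cc(-c3ccc(C(C)CC(=O)O)cc3)ncc12` is not yet measured. It differs from compound 2 by methyl in place of hydrogen on a saturated chain carbon bound to an aromatic carbon and a saturated chain carbon. This is the same kind of change as from compound 1 to compound 3, but not the same: there the carbon sits bound to an aromatic carbon only, here it is bound to an aromatic carbon and a saturated chain carbon, on the acid chain rather than on the core. Going by the values given here, the only measured precedent, a 1.3-fold lower number from compound 1 to compound 3 (0.10 log units; within the scatter), rests on one pair and sits within the scatter, so a step of similar small size is expected, a 1.3-fold lower number from compound 2 to compound 4 (0.12 log units; within the scatter), with added uncertainty because the place is not the same. In this assay compound 4 is therefore expected to give about 7000 nM, estimated to lie between 3000 nM and 20000 nM.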

Compound 4, half-maximal effective concentration: 61000 nM
Estimate against measurement, compound 4: 8.7-fold (0.94 log units) below; measured number above the stated range.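

In this assay, methyl in place of hydrogen on a saturated chain carbon bound to an aromatic carbon and a saturated chain carbon gives a 6.6-fold higher number from compound 2 to compound 4 (0.82 log units; beyond the scatter), and this step does not match the earlier one: the same change on two cores in this assay, a 1.3-fold lower number (0.10 log units; within the scatter) from compound 1 to compound 3 and a 6.6-fold higher number (0.82 log units; beyond the scatter) from compound 2 to compound 4, 8.4-fold (0.93 log units) apart, beyond the scatter of two such steps.

The small step seen on the core of compound 1 therefore does not predict the result on the core of compound 2, so in this series a change of this kind cannot simply be carried from one core to another. The comparison does not show why the steps differ, since they differ in both core and place: one methyl enters on the alkyl chain of the shared bicyclic scaffold and the other on the acid chain, and each step rests on a single pair.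

Still open, going by these compounds, is whether 1-(carboxymethyl)ethyl in place of 2-carboxyethyl on the core of compound 1 gives a step like the one on the core of compound 2, and whether the ethyl group of compound 3 behaves on the core of compound 2 as it does on the core of compound 1. Also open, on these data alone, is how a hydroxyl group or a longer chain at the same acid-chain carbon compares with methyl.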